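The source may report more compounds than this note shows. Statements on the series, on what has been measured and on what is new or still open speak of the compounds shown alone.

In an ADME assay on microsomes from liver (Homo sapiens) for metabolic stability, read by LC-MS, with NADPH named in the record, with a stated time of 60 min, tested at 1 uM, in the absence of a further agent (a higher number here means that more of the compound is left, a lower number that less of the compound is left), the series reads as follows:
compound 1 `COc1ccc(-c2c(C)nc3c(N4CC[C@@H](NC(C)=O)C4)cc(C)nn23)cc1OC` gives > 95%
compound 2 `COc1ccc(-c2c(C)nc3c(N4CC[C@@H](NC(=O)COc5ccccc5)C4)cc(C)nn23)cc1OC` gives > 95%
compound 3 `COc1ccc(-c2c(C)nc3c(N4CC[C@@H](NS(=O)(=O)c5ccc(C#N)cc5)C4)cc(C)nn23)cc1OC` gives > 95%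

Each entry is a limit and not a number, as the limit of > 95% in this assay, at which 3 of the 3 values shown sit, shows for the whole set. Compound 3 therefore stands at a limit, with no number of its own. The change to compound 4 `COc1ccc(-c2c(C)nc3c(N4CC[C@@H](O)C4)cc(C)nn23)cc1OC` is hydroxy in place of ((4-cyanophenyl)sulfonyl)amino on a saturated ring carbon, counted as hydroxy in place of ((4-cyanophenyl)sulfonyl)amino on a saturated ring carbon for this swap. Bearing on it are a step that the two limits leave unreadable from compound 1 to compound 2 and a step that the two limits leave unreadable from compound 1 to compound 3 and a step that the two limits leave unreadable from compound 2 to compound 3 and none of them has a readable size. Compound 3 gives > 95% as a limit, so no change beyond the scatter is expected in this assay in either direction. The estimated move is a number no higher from compound 3 to compound 4 (the limit leaves the size open) and it is expected to stay within the scatter. Compound 4 is estimated at 95% within a range of 85% to 100% in this expectation.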

Compound 4, percent of the compound remaining: > 95%
Compound 4: a limit, no number (the forecaster's own chance of this, stated with the estimate: 65%); the middle value lies on the limit itself.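

No step among compound 1, compound 2, compound 3 and compound 4 can be read, because each value is a limit: the limit of > 95% in this assay, at which 4 of the 4 values shown sit.

The compounds shown leave open whether these groups differ at all in the percent of compound remaining.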